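Swapping a saturated ring amine for a pyridylmethyl amine

The source may report more compounds than this note shows. Statements on the series, on what has been measured and on what is new or still open speak of the compounds shown alone.

Measured compounds:
Compound 1, `Nc1ccccc1NC(=O)c1ccc(CSC(=S)N2CCN(c3ccc(Cl)cc3)CC2)cc1`, in a functional assay on A-375 cells (Homo sapiens) for antiproliferative activity, read by CCK-8 assay, with a stated time of 72 h, tested at 2 uM (on this read-out lower numbers stand for a weaker effect and higher numbers for a stronger effect at the one concentration tested), gives 32.2%.
Compound 2, `Nc1ccccc1NC(=O)c1ccc(CSC(=S)N2CCCc3ccccc32)cc1`, in this assay gives 26.5%.
Compound 3, `Nc1ccccc1NC(=O)c1ccc(CSC(=S)N2CCN(c3ccncc3)CC2)cc1`, in this assay gives 85.7%.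

Compound 2 has the lowest of the three numbers. Its nearest neighbour is compound 1, whose number is higher but only within the usual scatter, so the two cannot be told apart. Compound 3 is far above both: the step of a number 53.5 percentage points higher from compound 1 to compound 3 (beyond the scatter) is large and well beyond the scatter.

Compound 4, `CN(Cc1cccnc1)C(=S)SCc1ccc(C(=O)Nc2ccccc2N)cc1`, has not been measured. It differs from compound 2 in one place: methyl((pyridin-3-yl)methyl)amino in place of 1,2,3,4-tetrahydroquinolin-1-yl on a thiocarbonyl carbon. Within the data shown here, the only measured step is the one from compound 1 to compound 3, where a pyridin-4-yl replaced a 4-chlorophenyl on a ring nitrogen and the number rose sharply. That change is not the same as the present one, which sits on the thiocarbonyl carbon and brings in a six-membered aromatic ring with one hetero atom in place of the 1,2,3,4-tetrahydroquinolin-1-yl, so it is only a loose guide. On that guide, compound 4 is expected to show an upward step of a number 23.5 percentage points higher from compound 2 to compound 4 (beyond the scatter), with wide uncertainty. Compound 4 is therefore estimated at 50%, with a range from 20% to 80%.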

Compound 4, a percentage reported as inhibition, at one concentration (the size of the read-out at that concentration, not a potency): 39.4%
The estimate for compound 4 lay 10.6 percentage points above the measured number, and the stated range covers the measured number.
By their numbers in this assay, from the lowest: compounds 2, 1 and 4 (each within the scatter of the next, the first and the last beyond it); then compound 3.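

Measured by this assay the swap on the thiocarbonyl carbon gives a number 12.9 percentage points higher from compound 2 to compound 4 (beyond the scatter) and is a modest step, the first seen at this place, since the earlier step concerned a group on a ring nitrogen. It also shows that the two-ring 1,2,3,4-tetrahydroquinolin-1-yl is not needed for activity here, as methyl((pyridin-3-yl)methyl)amino, with its single aromatic ring holding a hetero atom, takes its place and the number rises. Several things change together in this one swap, including the ring count, the hetero atom in the aromatic ring and the hydrogen-bond acceptor that the entering group carries, and nothing available explains the rise or ties it to any one of them.

The compounds shown leave open whether the placement of the pyridine nitrogen matters, which a pyridin-4-ylmethyl or pyridin-2-ylmethyl group on the same amine would test, and whether that nitrogen matters at all, which a plain benzyl group would test. They also leave open what the methyl on the amine contributes, which a hydrogen or an ethyl group in its place could show.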